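The source may report more compounds than this note shows. Statements on the series, on what has been measured and on what is new or still open speak of the compounds shown alone.

Going by the values given here, compound 1 `O=C(NCCCCN1CCN(c2ccc(Cl)cc2)CC1)c1ccc(-c2ccsc2)cc1` is one of two compounds measured in an ADME assay on microsomes from liver (Rattus norvegicus) for metabolic stability, read by LC-MS, using NADPH (a higher number here means that the compound lasts longer, a lower number that the compound disappears faster), and in this assay compound 1 gives 0.837 h, the highest of the two numbers. Among the compounds with values here, the only other measured compound, compound 2 `COc1cccc(N2CCN(CCCCNC(=O)c3ccc(-c4ccsc4)cc3)CC2)c1`, gives 0.155 h in this assay. Within the data shown here, the one measured step in this assay, a 5.4-fold lower number from compound 1 to compound 2 (0.73 log units; beyond the scatter), shows that exchanging the group on the amine nitrogen in the ring can move the half-life by a clearly readable amount.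

The unmeasured compound 3 `N#Cc1cccc(N2CCN(CCCCNC(=O)c3ccc(-c4ccsc4)cc3)CC2)c1` differs from compound 1 in the same place: 3-cyanophenyl in place of 4-chlorophenyl on an amine nitrogen in a ring. Among the measured compounds shown here, no step with a 3-cyanophenyl at this position has been measured, so the only guide is the step from compound 1 to compound 2, which also replaced the 4-chlorophenyl and lowered the number well beyond the scatter. For the measured compounds named here, on that basis compound 3 is expected to show a lower number than compound 1 in this assay, by a step of about a 2.4-fold lower number from compound 1 to compound 3 (0.38 log units; beyond the scatter), though smaller than the one seen for compound 2. Compound 3 is therefore estimated at 0.35 h, with a plausible range from 0.12 h to 0.9 h.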

Compound 3, half-life: > 1 h
Compound 3 ended at the assay's limit; the forecaster's own chance of this, stated with the estimate: 5%; middle value at least 2.8-fold (0.45 log units) away from the limit.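

In this assay compound 3 gives > 1 h, which is a limit of the assay and not a number. The step of an at least 6.4-fold higher number from compound 2 to compound 3 (0.80 log units; beyond the scatter) shows that, with the rest of the molecule unchanged, the half-life in this series turns on which group the phenyl ring on the amine nitrogen carries: cyano in place of methoxy on an aromatic carbon is enough to produce a change beyond the scatter. The step of an at least 1.1-fold higher number from compound 1 to compound 3 (0.07 log units; that floor lies within the scatter) shows that leaving the 4-chlorophenyl does not in itself bring the fall seen for the 3-methoxyphenyl, although its floor lies within the scatter, so no order between these two compounds can be stated and the true size of the step stays unread: the limit of > 1 h in this assay, at which 1 of the 3 values shown sits.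

The compounds shown leave open whether the group itself or its place on the phenyl ring matters more, a question that a 3-chlorophenyl or a 4-cyanophenyl on the same nitrogen would address. They also leave open how other groups on this phenyl ring, such as fluoro or trifluoromethyl, or a pyridine ring in place of the phenyl ring, would read in this assay.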